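Carbonyl substituent series: pyrazolyl to triazolyl

The compounds below may be only part of what the source reports. "The series", "measured", "known", "first", "only" and "open" are said of these compounds alone.

Measured so far:
- compound 1 `O=C(C1CCN(C(=O)C(F)(F)F)CC1)N1N=CCC1c1ccccc1`: in an ADME assay on microsomes (Homo sapiens) for metabolic stability (a lower number here means that the compound disappears faster, a higher number that the compound lasts longer), compound 1 gives > 1.5 h, a limit of the assay and not a number.
- compound 2 `CCC(=O)N1CCC(C(=O)N2N=CCC2c2ccccc2)CC1`: in this assay compound 2 gives > 2.75 h, again a limit.
- compound 3 `O=C(c1cc[nH]n1)N1CCC(C(=O)N2N=CCC2c2ccccc2)CC1`: in this assay compound 3 gives > 2.75 h, also a limit.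

Compound 3 therefore stands at the limit of > 2.75 h in this assay, at which 2 of the 3 values shown sit, and no value in this set is a number. For the measured compounds named here, the steps that bear on the carbonyl substituent, a step that the two limits leave unreadable from compound 1 to compound 3 and a step that the two limits leave unreadable from compound 2 to compound 3, are both unreadable for that reason, as is a step that the two limits leave unreadable from compound 1 to compound 2; none of them shows whether ethyl, trifluoromethyl or 1H-pyrazol-3-yl on that carbonyl carbon moves the half-life at all.

Compound 4 `O=C(c1c[nH]nn1)N1CCC(C(=O)N2N=CCC2c2ccccc2)CC1` carries the change (1H-1,2,3-triazol-4-yl in place of 1H-pyrazol-3-yl on a carbonyl carbon). With every measured neighbour sitting at a limit, no step size or direction can be derived for this change, and the expectation is that compound 4 again reaches or exceeds the limit in this assay rather than giving a readable step, so the step that the limit leaves unreadable from compound 3 to compound 4 is expected to be within the scatter. The estimate for compound 4 is 3 h, with a range from 1.5 h to 6 h.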

Compound 4, half-life: > 2.75 h
Compound 4: only a limit was reported; the forecaster's own chance of this, stated with the estimate: 70%; the middle value does not contradict the limit.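

In this assay compound 4 gives > 2.75 h, a limit of the assay and not a number. Its steps from compound 1, compound 2 and compound 3 cannot be read. The compounds shown leave open whether trifluoromethyl, ethyl, 1H-pyrazol-3-yl or 1H-1,2,3-triazol-4-yl on that carbonyl carbon changes the half-life at all.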